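The source may report more compounds than this note shows. Statements on the series, on what has been measured and on what is new or still open speak of the compounds shown alone.

In a functional assay on MCF7 cells (Homo sapiens) for inhibition, with a stated time of 48 h (on this read-out lower numbers stand for stronger inhibition and higher numbers for weaker inhibition), compound 3 (`COc1cc(Sc2c[nH]c3ccc(I)cc23)cc(OC)c1OC`) gives 68 nM. That number lies within the scatter of compound 2 (`COc1cc(Sc2c[nH]c3ccc(Br)cc23)cc(OC)c1OC`), which gives 43 nM. Compound 1 (`Cc1cc(C)cc(Sc2c[nH]c3ccc(Cl)cc23)c1`) differs from compound 3 in more than one place, and compound 1 stands far higher at 1200 nM.

The next structure is compound 4 (`COc1cc(Sc2c[nH]c3ccc([N+](=O)[O-])cc23)cc(OC)c1OC`), which carries nitro in place of iodo on an aromatic carbon. Within the data shown here, only one measured step changes a single group at this place, namely a 1.6-fold higher number from compound 2 to compound 3 (0.20 log units; within the scatter). Among the measured compounds shown here, that step exchanges bromo for iodo, so it offers only a weak guide to nitro, and no measured compound carries a nitro group. With so little to go on, a modest move toward a higher number in this assay is expected, with wide uncertainty that includes no change beyond the scatter. The expected step is a 2.2-fold higher number from compound 3 to compound 4 (0.34 log units; beyond the scatter). Compound 4 is therefore estimated at 150 nM, with an expected range from 40 nM to 600 nM.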

Compound 4, half-maximal inhibitory concentration: 560 nM
Compound 4: middle estimate off by 3.7-fold (0.57 log units), on the low side; low and high end bracket the measured number.
By their numbers in this assay, from the lowest: compounds 2 and 3 (each within the scatter of the next); then compound 4; then compound 1.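

At this place, on an aromatic carbon of a six-membered aromatic ring of carbon only, the exchange of bromo for iodo had left the number in this assay within the scatter. Nitro behaves differently: it gives an 8.2-fold higher number from compound 3 to compound 4 (0.92 log units; beyond the scatter) and a 13-fold higher number from compound 2 to compound 4 (1.11 log units; beyond the scatter) and both steps lie beyond the scatter. The position therefore does not accept every group alike, a sensitivity that compounds 2 and 3 alone did not reveal, and nothing shown explains the change.

The compounds shown leave open whether an amine, a nitrile or a methoxy group at this place would stay close to bromo and iodo or move as far as nitro. From the compounds shown here alone, whether a carboxylic acid or a plain hydrogen here would raise the number further also stays open.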